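Amide-side aryl swap in a pyrazolopyridine cytotoxicity series

The source may hold more compounds than are shown below. What is called first, only, known or untested is meant among the compounds shown, and "the series" means these compounds.

Of the compounds shown here, two have been measured. In a functional assay on THP-1 cells (Homo sapiens) for cytotoxicity, read by MTT assay, with a stated time of 24 h (on this read-out lower numbers stand for stronger inhibition and higher numbers for weaker inhibition), compound 1 `COc1ccc(NC(=O)Cn2cc(Cn3nc(N)c4c(C(F)(F)F)cc(-c5ccccc5)nc43)nn2)cc1` gives 56.7 ug/mL, and compound 2 `Cc1ccc(NC(=O)Cn2cc(Cn3nc(N)c4c(C(F)(F)F)cc(-c5ccccc5)nc43)nn2)cc1` gives 41.5 ug/mL; the two sit within the scatter of each other, so compound 2 stands alongside compound 1 rather than apart from it. Going by the values given here, the only measured step, a 1.4-fold lower number from compound 1 to compound 2 (0.14 log units; within the scatter), concerns the aromatic carbon substituent and not the amide side. Compound 3 `Nc1nn(Cc2cn(CC(=O)Nc3c(F)cccc3F)nn2)c2nc(-c3ccccc3)cc(C(F)(F)F)c12` carries 2,6-difluorophenyl in place of 4-methylphenyl on an amide-type nitrogen. Among the compounds with values here, no measured step touches this position, so no shift beyond the scatter is expected, and a 1.1-fold higher number from compound 2 to compound 3 (0.04 log units; within the scatter) is the estimated step. Compound 3 is expected at 45 ug/mL, within 20 ug/mL to 100 ug/mL.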

Compound 3, half-maximal inhibitory concentration: 43.3 ug/mL
The estimate for compound 3 lay 1.0-fold (0.02 log units) above the measured number, and the stated range covers the measured number.
By their numbers in this assay, from the lowest: compounds 2, 3 and 1 (each within the scatter of the next).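

In this assay, 2,6-difluorophenyl in place of 4-methylphenyl on the amide-type nitrogen gives a 1.0-fold higher number from compound 2 to compound 3 (0.02 log units; within the scatter) and 2,6-difluorophenyl in place of 4-methoxyphenyl gives a 1.3-fold lower number from compound 1 to compound 3 (0.12 log units; within the scatter) on the same position. This position therefore accepts all three aryl groups shown with no step beyond the scatter, and these are the first steps read there. No supporting data bear on this result.

Going by these compounds, whether an aryl-free group on this nitrogen, such as an amine or a carboxylic acid-bearing chain, would stay within the scatter remains open.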